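Chloro for Hydrogen on a Weakly Cytotoxic Core

The source may report more compounds than this note shows. Statements on the series, on what has been measured and on what is new or still open speak of the compounds shown alone.

Compound 1 `CCn1c(/C=C2/C(=O)Nc3ccccc32)nc2ccccc21` is one of two compounds with a measured value here. In a functional assay on PC-3 cells (Homo sapiens) for cytotoxicity, read by MTT assay, with a stated time of 48 h (on this read-out higher numbers stand for weaker inhibition and lower numbers for stronger inhibition), compound 1 gives 38000 nM, the higher of the two numbers. Compound 2 `Cn1c(/C=C2/C(=O)Nc3ccc(F)cc32)nc2ccccc21`, a close relative, gives 34300 nM in this assay; the two values lie within the scatter of each other, so neither can be called the stronger. Going by the values given here, no single-point step between measured compounds is available, which leaves the effect of any one change open.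

Compound 3 `CCn1c(/C=C2/C(=O)Nc3ccc(Cl)cc32)nc2ccccc21` differs from compound 1 in one place: chloro in place of hydrogen on an aromatic carbon. With only two weak, near-identical values to go on, the expected step from compound 1 to compound 3 in this assay is small and uncertain, a 1.5-fold lower number from compound 1 to compound 3 (0.18 log units; within the scatter), possibly a modest gain or nothing beyond the scatter. Compound 3 is therefore estimated at 25000 nM, with a range from 8000 nM to 70000 nM.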

Compound 3, half-maximal inhibitory concentration: > 50000 nM
Compound 3 gave a limit, no number; the forecaster's own chance of this, stated with the estimate: 15%; middle value at least 2.0-fold (0.30 log units) from the limit.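

Compound 3 carries a limit, not a number: the limit of > 50000 nM in this assay, at which 1 of the 3 values shown sits. Setting chloro in place of hydrogen on this aromatic carbon, meta to a fused ring and para to a fused ring, brings no sign of stronger inhibition in this assay; the step is an at least 1.3-fold higher number from compound 1 to compound 3 (0.11 log units; that floor lies within the scatter). Going by these compounds alone, this is the only direct look at a single change on the shared core, and because its floor lies within the scatter, it rules out a clear gain from chloro here but does not establish a real loss.

Going by these compounds, how far compound 3 truly lies from compound 1 stays unknown, since the limit sets only a floor for the step. Also open, on these data alone, is whether a different group at this position, such as an amine or a carboxylic acid, would give stronger inhibition on this core.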